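Swapping the aryl group on a thiazole acid scaffold

The source may hold more compounds than are shown below. What is called first, only, known or untested is meant among the compounds shown, and "the series" means these compounds.

Of the compounds shown here, three sharing one core have been tested in an in vitro functional assay on HEK285-7 cells for antagonist activity at prostaglandin D2 receptor 2 (Homo sapiens), read by BRET and beta-arrestin recruitment; on this read-out higher numbers stand for weaker inhibition and lower numbers for stronger inhibition. Compound 1 `N#Cc1cc(-c2nc(C(c3ccc(F)cc3)c3ccc(F)cc3)sc2CC(=O)O)ccc1F` gives 520 nM, the highest of the three numbers. Compound 2 `O=C(O)Cc1sc(C(c2ccc(F)cc2)c2ccc(F)cc2)nc1-c1ccco1`, in which furan-2-yl replaces 3-cyano-4-fluorophenyl on an aromatic carbon, gives 140 nM, and compound 3 `O=C(O)Cc1sc(C(c2ccc(F)cc2)c2ccc(F)cc2)nc1-c1ccnc(Cl)c1`, which carries 2-chloropyridin-4-yl at the same place, gives 39 nM. Both steps away from compound 1 run downward: a 3.7-fold lower number from compound 1 to compound 2 (0.57 log units; beyond the scatter) and a 13-fold lower number from compound 1 to compound 3 (1.12 log units; beyond the scatter), and between the two replacements a 3.6-fold lower number from compound 2 to compound 3 (0.56 log units; beyond the scatter).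

Compound 4 `O=C(O)Cc1sc(C(c2ccc(F)cc2)c2ccc(F)cc2)nc1-c1ccc(Cl)cc1` is the next member, not yet measured. It differs from compound 1 in one place: 4-chlorophenyl in place of 3-cyano-4-fluorophenyl on an aromatic carbon. The two measured steps from compound 1 are the ones that bear on this change, since each also removes the 3-cyano-4-fluorophenyl group and each lowered the number by a modest to large amount. On that basis the author expects a further downward step, a 4.3-fold lower number from compound 1 to compound 4 (0.64 log units; beyond the scatter), in this assay, though it is uncertain whether a plain 4-chlorophenyl group will reach as far as the 2-chloropyridin-4-yl of compound 3. The estimate for compound 4 is therefore 120 nM, with a range from 40 nM to 350 nM.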

Compound 4, half-maximal inhibitory concentration: 180 nM
Estimate against measurement, compound 4: 1.5-fold (0.18 log units) below; low and high end bracket the measured number.
By their numbers in this assay, from the lowest: compound 3; then compounds 2 and 4 (each within the scatter of the next); then compound 1.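

The 3-cyano-4-fluorophenyl group and the 4-chlorophenyl group each place one six-membered aromatic ring of carbon only on the thiazole-bearing position, so a 2.9-fold lower number from compound 1 to compound 4 (0.46 log units; beyond the scatter) shows that in this assay the number at this position can fall without any change in that ring type, unlike the steps to the furan-2-yl and 2-chloropyridin-4-yl groups. Chlorine on the ring does not by itself account for the low number of compound 3: with a ring of carbon only in place of the 2-chloropyridin-4-yl ring there is a 4.6-fold higher number from compound 3 to compound 4 (0.66 log units; beyond the scatter), whereas 4-chlorophenyl and furan-2-yl cannot be told apart, with a 1.3-fold higher number from compound 2 to compound 4 (0.11 log units; within the scatter). Nothing shown here accounts for any of these steps.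

The step from compound 1 to compound 4 removes the nitrile and the fluorine and adds the chlorine all at once, so the share of each remains unresolved, and a plain phenyl group would help to separate them. Also open, from the compounds shown here alone, is how the number would respond to a pyridine ring without chlorine, or to an amine in place of that chlorine.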